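The compounds below may be only part of what the source reports. "The series", "measured", "known", "first", "only" and "open" are said of these compounds alone.

Compound 1 `CC1=C(C(=O)Nc2ccc(F)cc2)C(c2ccc([N+](=O)[O-])cc2)N=C(SCc2ccccc2)N1`: 32.3%
Compound 2 `CC1=C(C(=O)Nc2ccc(F)cc2)C(c2ccc([N+](=O)[O-])cc2)N=C(SCc2cccc(Cl)c2)N1`: 16.4%
Compound 3 `COc1ccc(C2N=C(SCc3ccccc3)NC(C)=C2C(=O)Nc2ccc(Br)cc2)cc1`: 11.3%

In a functional assay on the whole organism (artery, strain albino) with Rattus norvegicus as the target, with a stated time of 600 min, at a dose of 10 mg/kg by the oral route (a lower number here means less inhibition, a higher number more inhibition at the dose given (going by the name of the read-out)), compound 1 gives 32.3%, compound 2 gives 16.4% and compound 3 gives 11.3%. Between compound 1 and compound 2 the change is chloro in place of hydrogen on an aromatic carbon, and this brings a number 15.9 percentage points lower from compound 1 to compound 2 (beyond the scatter). Compound 3 lies within the scatter of compound 2 and gives a lower number than compound 1. How the core of compound 3 differs from the core of compound 1 is not broken down here.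

Compound 4 `COc1ccc(C2N=C(SCc3ccccc3Cl)NC(C)=C2C(=O)Nc2ccc(Br)cc2)cc1` is not yet measured. It differs from compound 3 by chloro in place of hydrogen on an aromatic carbon. Within the data shown here, this is the same kind of change as the one from compound 1 to compound 2, but the place differs: there the chloro sits meta to a large group, here ortho to a large group. The earlier step was downward, and compound 3 already gives 11.3%, a low number that leaves little room for a further fall. The step is therefore expected to be smaller, estimated at a number 6.3 percentage points lower from compound 3 to compound 4 (within the scatter). Compound 4 is therefore expected to give about 5%, with a likely range from 0% to 16%.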

Compound 4, a percentage reported as inhibition, in the whole organism at one dose (the size of the read-out at that dose, not a potency): 13.3%
For compound 4 the middle estimate is 8.3 percentage points below the measured one; low and high end bracket the measured number.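

In this assay, chloro in place of hydrogen on the benzyl group gives a number 2 percentage points higher from compound 3 to compound 4 (within the scatter), and set beside the earlier step, the change does not carry over unchanged from one core to the other: the same change on two cores in this assay, a number 15.9 percentage points lower (beyond the scatter) from compound 1 to compound 2 and a number 2 percentage points higher (within the scatter) from compound 3 to compound 4, 17.9 percentage points apart, beyond the scatter of two such steps This is not a clean test of the core alone, however: in compound 4 the chloro sits ortho to a large group, whereas in compound 2 it stands at another place on the ring, so the core and the place of the chloro change together and cannot be separated here. Among these compounds, with only one such pair on each core, these steps do not show how the change would behave on any further core.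

The compounds shown leave open how the read-out would respond to other groups on the benzyl ring, such as a methyl or a nitrile. They also leave open what an amine or a carboxylic acid would do in place of the benzylsulfanyl group on the shared core.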